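This account rests on a few compounds, and the source may have more. Where it says the series, first, only, none or still open, it means among the compounds named here.

Working notes on the series in a functional assay on A549 cells (Homo sapiens) for cytotoxicity, read by MTT assay, with a stated time of 7 days; a higher number here means that more compound is needed for the effect, a lower number that less compound is needed. Of the compounds shown here, three have a number so far. Compound 1 `C=C(C)[C@@H]1Oc2cc(O)c(C(C)=O)cc2[C@H]1OC` gives 31 ug/mL in this assay. Compound 2 `COC(C)(C)/C=C/c1cc(C(C)=O)ccc1O[C@@H]1O[C@H](CO)[C@@H](O)[C@H](O)[C@H]1O` gives 6 ug/mL. Compound 3 `CC(=O)c1cc2c(cc1O)OC(C)(C)C=C2` gives 10 ug/mL, the second highest of the three numbers; its gap to compound 2 is within the usual scatter of repeat measurements, while its gap to compound 1 lies beyond it, compound 1 needing more material for the same effect. Among the compounds with values here, no two of the measured compounds differ from one another in a single place, so no measured step is at hand to calibrate the next change.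

Compound 4 `COc1cc2c(cc1C(C)=O)C=CC(C)(C)O2` is the next to be run in this assay. It differs from compound 3 by methyl in place of hydrogen on an oxygen on an aromatic ring. Within the data shown here, nothing among the measured compounds shows what this change does in this assay, so the expectation rests on compound 3 alone. The step from compound 3 to compound 4 is estimated at a 1.5-fold higher number from compound 3 to compound 4 (0.18 log units; within the scatter), that is, a move expected to stay within the scatter, if anything toward a somewhat higher number. Compound 4 is thus expected at 15 ug/mL, with a range from 5 ug/mL to 45 ug/mL.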

Compound 4, concentration for half-maximal effect: 25 ug/mL
Compound 4: middle estimate off by 1.7-fold (0.22 log units), on the low side; measured number inside the range.
By their numbers in this assay, from the lowest: compounds 2 and 3 (each within the scatter of the next); then compounds 4 and 1 (each within the scatter of the next).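

Replacing hydrogen with methyl on the oxygen on an aromatic ring, hydroxy to methoxy, gives the series its first single-place comparison: in this assay it produces a 2.5-fold higher number from compound 3 to compound 4 (0.40 log units; beyond the scatter). The free hydroxy of compound 3 therefore cannot be exchanged for methoxy without a shift in the read-out, and the shift runs toward more compound being needed for the effect, a direction and size that compounds 1 to 3 could not show since none of them differ in one place. The data offer no measured property to account for this shift, and it remains a bare observation from one pair.

Still open, on these data alone, is whether the shift follows from the loss of the hydrogen or from the methyl itself, which an ethyl group, a longer chain or an acetyl group on the same oxygen would help to separate. Also open, as far as these compounds go, is whether hydroxy to methoxy moves the number in the same direction on the core of compound 1, where the same hydroxy stands, as this single pair gives no reading beyond the core shared by compound 3 and compound 4.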